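Swapping the aryl ring on the cyclopropane of compound 3

A few compounds are considered here, and "the series" means these few. Any claim that something is new, unique, unknown or untested is made for them only; others in the source may bear on it.

Measured compounds:
- compound 1 `CC(C)CCNCCN(C(=O)[C@@H]1C[C@H]1c1ccccc1)c1ccc(-c2ccccc2)cc1`: 5.1 nM
- compound 2 `CC[C@H](C)[C@H](N)CN(C(=O)[C@@H]1C[C@H]1C1CCCCC1)c1ccc(-c2ccccc2)cc1`: > 25000 nM (a limit of the assay, not a number)
- compound 3 `CC[C@H](C)[C@H](N)CN(C(=O)[C@@H]1C[C@H]1c1cc(F)ccc1F)c1ccc(-c2ccccc2)cc1`: 770 nM

In a functional assay for agonist activity at G protein-coupled receptor 88 (Homo sapiens), read by HTRF and cAMP accumulation (on this read-out higher numbers stand for an effect only at larger amounts of compound and lower numbers for an effect already at smaller amounts), compound 3 gives the highest of the two numbers shown; compound 1 sits far lower. Compound 4 `CC[C@H](C)[C@H](N)CN(C(=O)[C@@H]1C[C@H]1c1nc(C)cs1)c1ccc(-c2ccccc2)cc1` is not yet measured; it differs from compound 3 in one place: 4-methyl-1,3-thiazol-2-yl in place of 2,5-difluorophenyl on a saturated ring carbon. For the measured compounds named here, the only measured step at this position is an at least 32-fold lower number from compound 2 to compound 3 (1.51 log units; beyond the scatter), where an aromatic ring replaced a saturated one. Here one aromatic ring replaces another, so that step gives only indirect guidance. A modest shift in either direction is expected, with the move from compound 3 to compound 4 estimated as a 1.9-fold higher number from compound 3 to compound 4 (0.29 log units; within the scatter). Compound 4 is expected to give about 1500 nM, between 300 nM and 8000 nM.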

Compound 4, half-maximal effective concentration: 730 nM
Compound 4: middle estimate off by 2.1-fold (0.31 log units), on the high side, within the range that was stated.
By their numbers in this assay, from the lowest: compound 1; then compounds 4 and 3 (each within the scatter of the next). At a limit, above all of these: compound 2.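

In this assay the exchange of one aromatic ring for another gives a 1.1-fold lower number from compound 3 to compound 4 (0.02 log units; within the scatter), so a five-membered aromatic ring with 2 hetero atoms serves at this cyclopropane carbon as well as 2,5-difluorophenyl does. The step from cyclohexyl gives an at least 34-fold lower number from compound 2 to compound 4 (1.53 log units; beyond the scatter), so this large step is not tied to one particular aromatic ring. The value of compound 2 is a limit, not a number: the limit of > 25000 nM in this assay, at which 1 of the 4 values shown sits.

Going by these compounds, whether a pyridine ring would fit this carbon equally well remains open. So does whether a carboxylic acid on the ring would be accepted.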